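Swapping a substituted aryl group for a pyridine

This account rests on a few compounds, and the source may have more. Where it says the series, first, only, none or still open, it means among the compounds named here.

Measured compounds:
Compound 1 `COc1ccc(S(=O)(=O)N2CCc3cccc(-c4ccc(N)cc4)c32)cc1` — 162 nM
Compound 2 `COc1ccc(S(=O)(=O)N2CCc3cccc(-c4ccc(F)nc4)c32)cc1` — 145 nM
Compound 3 `COc1ccc(S(=O)(=O)N2CCc3cccc(-c4ccc(N(C)C)cc4)c32)cc1` — 237 nM

In a functional assay on MKN-45 cells (Homo sapiens) for inhibition, with a stated time of 72 h (a higher number here means a weaker inhibitor, a lower number a stronger inhibitor), compound 1 gives 162 nM, the second highest of the three numbers, with compound 2 nearest (a 1.1-fold lower number from compound 1 to compound 2 (0.05 log units; within the scatter)) and compound 3 furthest (a 1.5-fold higher number from compound 1 to compound 3 (0.17 log units; within the scatter)). Compound 4 `COc1ccc(S(=O)(=O)N2CCc3cccc(-c4ccncc4)c32)cc1` differs from compound 1 by pyridin-4-yl in place of 4-aminophenyl on an aromatic carbon. The step of a 1.1-fold lower number from compound 1 to compound 2 (0.05 log units; within the scatter) also replaces the 4-aminophenyl with a ring holding one hetero atom and no donor, and it stayed within the scatter; a 1.6-fold higher number from compound 2 to compound 3 (0.21 log units; within the scatter) and a 1.5-fold higher number from compound 1 to compound 3 (0.17 log units; within the scatter) were likewise within the scatter. All three steps change this same group without moving the number beyond the scatter, so no step beyond the scatter is expected here either. Compound 4 is therefore estimated at 180 nM, range 80 nM to 400 nM, a step of a 1.1-fold higher number from compound 1 to compound 4 (0.05 log units; within the scatter).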

Compound 4, half-maximal inhibitory concentration: 69.5 nM
Compound 4: middle estimate off by 2.6-fold (0.41 log units), on the high side; measured number below the stated range.
By their numbers in this assay, from the lowest: compound 4; then compounds 2, 1 and 3 (each within the scatter of the next).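

In this assay, among the compounds shown here, the pyridin-4-yl group is the first at this aromatic carbon to shift the number beyond the scatter, with a 2.3-fold lower number from compound 1 to compound 4 (0.37 log units; beyond the scatter) against 4-aminophenyl, a 3.4-fold lower number from compound 3 to compound 4 (0.53 log units; beyond the scatter) against 4-(dimethylamino)phenyl and a 2.1-fold lower number from compound 2 to compound 4 (0.32 log units; beyond the scatter) against 6-fluoropyridin-3-yl. A pyridine ring alone does not guarantee this, as compound 2 also carries one, yet its step from compound 1 stayed within the scatter. Nothing measured here explains the lower number of compound 4. Still open, as far as these compounds go, is how pyridin-3-yl or pyridin-2-yl would compare, and whether a methyl group on the pyridin-4-yl ring would keep the lower number.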